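This account rests on a few compounds, and the source may have more. Where it says the series, first, only, none or still open, it means among the compounds named here.

Compound 3 `Cc1cc(N2CC[C@@H](C)[C@@H](N(C)c3ncnc4[nH]ccc34)C2)n2nc(SCc3ccc(Br)cc3)nc2n1` gives 4020 nM in a functional assay on MGC-803 cells (Homo sapiens) for inhibition, read by MTT assay, with a stated time of 72 h (on this read-out lower numbers stand for stronger inhibition and higher numbers for weaker inhibition), the lowest of the three numbers. Compound 1 `Cc1cc(N2CC[C@@H](C)[C@@H](N(C)c3ncnc4[nH]ccc34)C2)n2nc(SCC3CCCCC3)nc2n1` gives 9170 nM and compound 2 `Cc1cc(N2CC[C@@H](C)[C@@H](N(C)c3ncnc4[nH]ccc34)C2)n2nc(SCc3ccc(Cl)cc3)nc2n1` gives 16000 nM; the steps to the lowest number are a 2.3-fold lower number from compound 1 to compound 3 (0.36 log units; beyond the scatter) and a 4.0-fold lower number from compound 2 to compound 3 (0.60 log units; beyond the scatter), both modest, while a 1.7-fold higher number from compound 1 to compound 2 (0.24 log units; within the scatter) stays within the scatter. Compound 4 `Cc1cc(N2CC[C@@H](C)[C@@H](N(C)c3ncnc4[nH]ccc34)C2)n2nc(SCCCc3ccccc3)nc2n1` carries phenethyl in place of 4-bromophenyl on a saturated chain carbon bound to a sulfur. Among the measured compounds shown here, no measured step tests this change directly; what bears on it is that the ring carrying bromine gave the lowest number and that the step of a 4.0-fold lower number from compound 2 to compound 3 (0.60 log units; beyond the scatter) turned on the halogen alone. Because of a 4.0-fold lower number from compound 2 to compound 3 (0.60 log units; beyond the scatter) the loss of that bromine is expected to raise the number. Compound 4 is therefore estimated at 10000 nM, with a range from 3000 nM to 30000 nM. This corresponds to an expected step of a 2.5-fold higher number from compound 3 to compound 4 (0.40 log units; beyond the scatter).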

Compound 4, half-maximal inhibitory concentration: > 100000 nM
Compound 4 gave a limit, no number (the forecaster's own chance of this, stated with the estimate: 10%); middle value at least 10-fold (1.00 log units) away from the limit.
By their numbers in this assay, from the lowest: compound 3; then compounds 1 and 2 (each within the scatter of the next). At a limit, above all of these: compound 4.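

Compound 4 stands at a limit of the assay, not at a number: the limit of > 100000 nM in this assay, at which 1 of the 4 values shown sits. Even so, the steps are an at least 24-fold higher number from compound 3 to compound 4 (1.39 log units; beyond the scatter), an at least 6.2-fold higher number from compound 2 to compound 4 (0.79 log units; beyond the scatter) and an at least 10-fold higher number from compound 1 to compound 4 (1.03 log units; beyond the scatter), each a lower bound on the true difference. So this position, where cyclohexyl, 4-chlorophenyl and 4-bromophenyl had shifted the number only modestly, can also lose nearly all measurable inhibition with the change to 3-phenylpropyl.

The compounds shown leave open whether the longer chain or the missing halogen accounts for this. An unsubstituted benzyl or a 3-(4-bromophenyl)propyl group would separate the two.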